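The source may hold more compounds than are shown below. What is called first, only, known or untested is meant among the compounds shown, and "the series" means these compounds.

Measured compounds in an assay for displacement of a labelled ligand from Sigma non-opioid intracellular receptor 1 (Cavia porcellus), read by scintillation counting; on this read-out lower numbers stand for stronger inhibition and higher numbers for weaker inhibition:
compound 1 `NCC[C@@H]1CCO[C@H](c2ccccc2)O1` gives 165 nM;
compound 2 `CNCC[C@@H]1CCO[C@H](c2ccccc2)O1` gives 449 nM.

On these two numbers compound 2 stands highest; its nearest neighbour is compound 1, and the step of a 2.7-fold higher number from compound 1 to compound 2 (0.43 log units; beyond the scatter) lies beyond the scatter. Compound 3 `c1ccc(CNCC[C@@H]2CCO[C@H](c3ccccc3)O2)cc1` has not been measured in this assay. It differs from compound 2 by phenyl in place of hydrogen on a saturated chain carbon bound to an amine nitrogen. For the measured compounds named here, the only measured step that touches the amine nitrogen is a 2.7-fold higher number from compound 1 to compound 2 (0.43 log units; beyond the scatter), a modest weakening when the nitrogen substituent grew from hydrogen to methyl. Going by the values given here, no measured pair shows what happens when that methyl is extended to benzyl, so the step is not directly anchored. Given that the one step near this position was only modest, compound 3 is expected to stay close to compound 2, with a 2.2-fold lower number from compound 2 to compound 3 (0.35 log units; beyond the scatter), though either direction remains open. The estimate for compound 3 in this assay is 200 nM, within 40 nM to 1000 nM.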

Compound 3, inhibition constant: 19 nM
The estimate for compound 3 lay 11-fold (1.02 log units) above the measured number; the measured number lies below the stated range.
By their numbers in this assay, from the lowest: compound 3; then compound 1; then compound 2.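

Notes on the amine nitrogen in this assay: extending methyl to benzyl gives the step (a 24-fold lower number from compound 2 to compound 3 (1.37 log units; beyond the scatter)), which runs opposite to the earlier step (a 2.7-fold higher number from compound 1 to compound 2 (0.43 log units; beyond the scatter)). Against the unsubstituted amine, benzyl also gives a lower number (an 8.7-fold lower number from compound 1 to compound 3 (0.94 log units; beyond the scatter)), so across these three compounds the read-out does not move in one direction as the nitrogen substituent grows: methyl raises the number and benzyl lowers it. Nothing available accounts for this reversal.

From the compounds shown here alone, it remains open whether the aromatic ring is what matters, or whether cyclohexylmethyl on the nitrogen would read like benzyl. Going by these compounds, the effect of a longer chain, such as phenylethyl, or of a substituent such as chloro on the phenyl ring, is also open.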